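Working notes on bombesin subtype-3 agonists: side-chain swap

A few compounds are considered here, and "the series" means these few. Any claim that something is new, unique, unknown or untested is made for them only; others in the source may bear on it.

Measured so far:
compound 1, `O=C(O)c1ccccc1-c1ccc(CCc2ncc(CC3CCCCC3)[nH]2)cc1`: 41 nM
compound 2, `CC(C)(C)Cc1cnc(CCc2ccc(-c3ccccc3C(=O)O)cc2)[nH]1`: 106 nM

In an in vitro functional assay on cells for agonist activity at Bombesin receptor subtype-3 (Homo sapiens), read by luminescence and calcium flux (a lower number here means that less compound is needed, a higher number that more compound is needed for the effect), compound 2 gives 106 nM, the higher of the two numbers here, and compound 1 gives 41 nM. Going by the values given here, the one measured step, a 2.6-fold higher number from compound 1 to compound 2 (0.41 log units; beyond the scatter), replaced a ring with a branched chain and raised the number modestly. Compound 3, `O=C(O)c1ccccc1-c1ccc(CCc2ncc(Cc3cccc(F)c3F)[nH]2)cc1`, carries 2,3-difluorophenyl in place of tert-butyl on a saturated chain carbon bound to an aromatic carbon. Among the compounds with values here, no measured step covers an aromatic ring at this position, so the expectation leans only on compound 1, where a ring gave the lower number; a modest lowering is expected, a 2.1-fold lower number from compound 2 to compound 3 (0.33 log units; beyond the scatter), with wide uncertainty. Compound 3 is expected at 50 nM, range 15 nM to 180 nM.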

Compound 3, half-maximal effective concentration: 87 nM
Compound 3: middle estimate off by 1.7-fold (0.24 log units), on the low side; the measured number falls inside the stated range.
By their numbers in this assay, from the lowest: compound 1; then compounds 3 and 2 (each within the scatter of the next).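

An aromatic ring on the saturated chain carbon does not by itself bring the number down: 2,3-difluorophenyl in place of tert-butyl gives a 1.2-fold lower number from compound 2 to compound 3 (0.09 log units; within the scatter), and in place of cyclohexyl it gives a 2.1-fold higher number from compound 1 to compound 3 (0.33 log units; beyond the scatter), so compound 1 keeps the lowest number of the three. Having a ring or not therefore does not sort this set, as compound 2 and compound 3 lie within the scatter of each other. Nothing at hand explains why cyclohexyl stands apart. Open, on these data alone, is how an unsubstituted phenyl or a chain bearing an amine would read at this place, and whether the two fluorines matter at all.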